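A few compounds are considered here, and "the series" means these few. Any claim that something is new, unique, unknown or untested is made for them only; others in the source may bear on it.

Working notes on the series around a shared core carrying an acetic acid side chain in compound 1 `O=C(O)COc1ccncc1-c1ccc2ccccc2c1` and a methylamide side chain in compound 2 `CNC(=O)COc1ccncc1-c1ccc2ccccc2c1`. In an assay on a protein complex for inhibition of CDK8/Cyclin C (Homo sapiens), with a stated time of 1 h (on this read-out lower numbers stand for stronger inhibition and higher numbers for weaker inhibition), compound 1 gives "not determined" (no result reported), and compound 2 gives "not determined" (no result reported) in this assay, so neither carries a number. Among the measured compounds shown here, compound 3 `CN(C)C(=O)/C=C/c1ccncc1-c1ccc2ccccc2c1` replaces the ether-linked side chain with a dimethylcarbamoyl-bearing ethenyl and is the only member with a result: in this assay compound 3 gives 30.1 nM. Compound 3 therefore stands alone on the numbers shown, with nothing to rank it against.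

Compound 4 `CCOC(=O)/C=C/c1ccncc1-c1ccc2ccccc2c1` keeps the ethenyl linker and changes the group on the carbonyl carbon: ethoxy in place of dimethylamino on a carbonyl carbon. For the measured compounds named here, no measured pair tells how such a change plays out here, so the expectation rests on the single value of compound 3 and on the modest size of the swap, which keeps the same count of heavy atoms. A small shift toward weaker inhibition is expected for compound 4, of a size near the scatter, as the step of a 2.0-fold higher number from compound 3 to compound 4 (0.30 log units; within the scatter) expresses. Compound 4 is accordingly estimated at 60 nM in this assay, within a range from 15 nM to 250 nM.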

Compound 4, half-maximal inhibitory concentration: 53.3 nM
Beside the measured number, compound 4's estimate is 1.1-fold (0.05 log units) above it, and the stated range covers the measured number.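

Ethoxy in place of dimethylamino on a carbonyl carbon is the first change in the series that can be read as a step, and in this assay it amounts to a 1.8-fold higher number from compound 3 to compound 4 (0.25 log units; within the scatter) on the shared core with the ethenyl linker held in place. The step from dimethylcarbamoyl to ethoxycarbonyl therefore shows that this position accepts an ester as well as a tertiary amide without a difference this read-out can separate from the scatter, even though a nitrogen gives way to an oxygen at the same heavy-atom count. Nothing measured on these compounds speaks to the reason for this result.

On these data alone, what remains open is how far this position stretches beyond these two groups: a carboxylic acid, a primary amide, a cyclic amine such as morpholine on the carbonyl carbon, or a longer alkyl chain on the ester could each move the number or leave it in place. The role of the ethenyl linker is open as well, since compound 1 and compound 2, with their ether-linked side chains, give no number to set against the ethenyl compounds, and a saturated two-carbon chain does not appear among the compounds shown.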